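Trimethoxy chalcones: chloro on the unsubstituted ring

The source may report more compounds than this note shows. Statements on the series, on what has been measured and on what is new or still open speak of the compounds shown alone.

Measured in a functional assay on NCI-H727 cells (Homo sapiens), read by fluorescence and BrdU incorporation, with a stated time of 48 h, tested at 10 uM; on this read-out higher numbers stand for a weaker effect at the one concentration tested and lower numbers for a stronger effect:
compound 1 `COc1cccc(/C=C/C(=O)c2c(OC)cc(OC)cc2OC)c1`, 37%
compound 2 `COc1cc(OC)c(C(=O)/C=C/c2ccccc2)c(OC)c1`, 34%

Compound 2 stands alongside compound 1 on the numbers shown: the step of a number 3 percentage points lower from compound 1 to compound 2 (within the scatter) lies within the scatter, and the two read alike. Compound 3 `COc1cc(OC)c(C(=O)/C=C/c2ccc(Cl)cc2)c(OC)c1` differs from compound 2 by chloro in place of hydrogen on an aromatic carbon, which, cut one bond further out, reads phenyl to 4-chlorophenyl. For the measured compounds named here, no measured step bears on this change directly; the only step seen, a number 3 percentage points lower from compound 1 to compound 2 (within the scatter), concerns methoxy on the same ring and stayed within the scatter, giving no direction. In this assay no step beyond the scatter is expected. Compound 3 is estimated at 34%, between 18% and 50%. The expected step is no change at the digits printed from compound 2 to compound 3 (within the scatter), within the scatter.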

Compound 3, a percentage reported as activity, at one concentration (the size of the read-out at that concentration, not a potency): 40%
Beside the measured number, compound 3's estimate is 6 percentage points below it; measured number inside the range.
By their numbers in this assay, from the lowest: compounds 2, 1 and 3 (each within the scatter of the next).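

Chloro in place of hydrogen on an aromatic carbon para to a large group gives a number 6 percentage points higher from compound 2 to compound 3 (within the scatter) in this assay, so this first substituent on the unsubstituted ring leaves the read-out inside the scatter. Comparing the two substituted rings, 4-chlorophenyl in place of 3-methoxyphenyl gives a number 3 percentage points higher from compound 1 to compound 3 (within the scatter) and again separates nothing.

As far as these compounds go, whether an amine or a carboxylic acid at this position would give a step beyond the scatter remains open. No measured evidence bears on these results.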